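Removing the aryl group from the amidine nitrogen

A few compounds are considered here, and "the series" means these few. Any claim that something is new, unique, unknown or untested is made for them only; others in the source may bear on it.

Measured compounds and values:
- compound 1 `Cc1ccc(S(=O)(=O)/N=C(/CCNC2=CC(=O)c3ccccc3C2=O)Nc2ccc(Cl)cc2)cc1`: 29900 nM
- compound 2 `Cc1ccc(S(=O)(=O)/N=C(/CCNC2=CC(=O)c3ccccc3C2=O)Nc2ccccc2I)cc1`: 24700 nM
- compound 3 `COc1ccc(N/C(CCNC2=CC(=O)c3ccccc3C2=O)=N\S(=O)(=O)c2ccc(C)cc2)c(OC)c1`: 126000 nM

All three values come from a functional assay on A549 cells (Homo sapiens) for cytotoxicity, read by MTT assay, with a stated time of 48 h; on this read-out lower numbers stand for stronger inhibition and higher numbers for weaker inhibition. Compound 2 has the lowest number of the three, though the step of a 1.2-fold lower number from compound 1 to compound 2 (0.08 log units; within the scatter) lies within the scatter; the step of a 5.1-fold higher number from compound 2 to compound 3 (0.71 log units; beyond the scatter) goes beyond it, as does a 4.2-fold higher number from compound 1 to compound 3 (0.62 log units; beyond the scatter).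

The next compound, compound 4 `Cc1ccc(S(=O)(=O)/N=C(\N)CCNC2=CC(=O)c3ccccc3C2=O)cc1`, differs from compound 2 in one place: hydrogen in place of 2-iodophenyl on an amine nitrogen.

Going by the values given here, none of the measured steps covers this change. Each of them swaps one aryl group for another on the same amine nitrogen; none removes the aryl group altogether. Among the compounds with values here, the only guidance is that changing the aryl group can shift the number by a modest amount, as in the step from compound 2 to compound 3, while a different swap left the number unchanged within the scatter.

Within the data shown here, with no direct precedent, the expected outcome is a weaker inhibitor, with a modest rise in the number, a 2.4-fold higher number from compound 2 to compound 4 (0.39 log units; beyond the scatter), together with a wide range. For compound 4 the estimated value in this assay is 60000 nM, with a range from 20000 nM to 200000 nM.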

Compound 4, half-maximal inhibitory concentration: 26600 nM
Estimate against measurement, compound 4: 2.3-fold (0.35 log units) above, within the range that was stated.
By their numbers in this assay, from the lowest: compounds 2, 4 and 1 (each within the scatter of the next); then compound 3.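

In this assay, an aryl group on this amine nitrogen proves dispensable among the compounds shown: with plain hydrogen there, the steps are a 1.1-fold higher number from compound 2 to compound 4 (0.03 log units; within the scatter) and a 1.1-fold lower number from compound 1 to compound 4 (0.05 log units; within the scatter), so hydrogen cannot be told apart from 2-iodophenyl or from 4-chlorophenyl. The third step, a 4.7-fold lower number from compound 3 to compound 4 (0.68 log units; beyond the scatter), is the only new one beyond the scatter, which suggests that the earlier gaps reflect the 2,4-dimethoxyphenyl group in particular, not aryl groups in general. Nothing measured here bears on why the 2,4-dimethoxyphenyl compound stands apart.

On these data alone, it remains open whether a small methyl group or a benzyl group on this amine nitrogen would give a number like that of compound 4, or would instead stand apart as the 2,4-dimethoxyphenyl compound does. It is also unclear whether a single methoxy group on the phenyl ring would be enough to separate a compound from compound 4, since the compounds shown carry either two methoxy groups or none.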